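Compound 1 to compound 4: naphthalen-1-yl exchanged

The compounds below may be only part of what the source reports. "The series", "measured", "known", "first", "only" and "open" are said of these compounds alone.

Values so far in a functional assay on THP-1 cells (Homo sapiens) for inhibition, read by sulforhodamine B assay, with a stated time of 48 h, tested at 50 uM (a higher number here means more inhibition of growth at the concentration tested, a lower number less inhibition of growth), are as follows.

compound 1 `COc1cc(/C=C/C(=O)/C=C/c2cccc3ccccc23)ccc1OCc1cn(CCOc2cc(=O)oc3ccccc23)nn1` gives 89%
compound 2 `COc1ccccc1/C=C/C(=O)/C=C/c1ccc(OCc2cn(CCCCOc3cc(=O)oc4ccccc34)nn2)c(OC)c1` gives 40%
compound 3 `COc1cc(/C=C/C(=O)/C=C/c2ccccc2)ccc1OCc1cn(CCCCCOc2cc(=O)oc3ccccc23)nn1` gives 26%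

Compound 1 stands highest of the three, and compound 2 and compound 3 both lie lower by more than the usual scatter. The next structure to test is compound 4 `COc1ccccc1/C=C/C(=O)/C=C/c1ccc(OCc2cn(CCOc3cc(=O)oc4ccccc34)nn2)c(OC)c1`, reached from compound 1 by one change (2-methoxyphenyl in place of naphthalen-1-yl on a double-bonded chain carbon bound to a double-bonded chain carbon), with 2-methoxyphenyl in place of naphthalen-1-yl on a double-bonded chain carbon bound to a double-bonded chain carbon.

Among the measured compounds shown here, no two measured compounds differ in one place only, so the data give no direct measure of this step. The nearest guide is compound 2, which also carries 2-methoxyphenyl and gives 40%, but it is only a loose guide, as its structure differs from compound 1 in more than this group. A fall beyond the scatter is expected, an estimated a number 29 percentage points lower from compound 1 to compound 4 (beyond the scatter) in this assay, although a smaller change cannot be ruled out. Compound 4 is estimated at 60%, with an expected range from 35% to 85% as the outcome.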

Compound 4, percent growth inhibition at one concentration: 75%
Beside the measured number, compound 4's estimate is 15 percentage points below it, and the stated range covers the measured number.
By their numbers in this assay, from the lowest: compound 3; then compound 2; then compound 4; then compound 1.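

In this assay, among the compounds shown here, placing 2-methoxyphenyl in place of naphthalen-1-yl on a double-bonded chain carbon bound to a double-bonded chain carbon gives a number 14 percentage points lower from compound 1 to compound 4 (beyond the scatter), a modest step and the one direct reading of this position so far. The position therefore keeps much of the growth inhibition when the two six-membered aromatic rings of naphthalen-1-yl give way to the single ring and one hydrogen-bond acceptor of 2-methoxyphenyl, and compound 4 gives 75% while compound 2, which carries the same 2-methoxyphenyl but differs in one other place, gives 40%. No measurement on hand accounts for the size of this step.

The step changes ring count, heavy atoms and the hydrogen-bond acceptor together, so the share of each stays unresolved, and plain phenyl appears only in compound 3, which gives 26% and differs from compound 1 in its chain as well. As far as these compounds go, how a 2-hydroxyphenyl or a pyridin-3-yl group would behave at this place remains open, as does whether the order seen at a single concentration would hold across a full concentration range.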